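Adding a Phenyl to the Benzyl Arm of Compound 1

The source may report more compounds than this note shows. Statements on the series, on what has been measured and on what is new or still open speak of the compounds shown alone.

Three compounds have been measured in a functional assay on the whole organism with Mus musculus as the target; on this read-out higher numbers stand for an effect only at larger amounts of compound and lower numbers for an effect already at smaller amounts:
compound 1 `NCc1nnc(Cc2ccccc2)s1`, 110 mg/kg
compound 2 `CC(N)c1nnc(-c2ccccc2-c2ccccc2)s1`, 21 mg/kg
compound 3 `CNCc1nnc(-c2ccccc2-c2ccccc2)s1`, 25 mg/kg

Compound 1 stands highest of these three numbers in this assay; its nearest neighbour is compound 3 and the furthest is compound 2, and both gaps lie beyond the scatter. Compound 4 `NCc1nnc(Cc2ccccc2-c2ccccc2)s1` keeps the core of compound 1 and differs from it in one place: phenyl in place of hydrogen on an aromatic carbon. Among the compounds with values here, the only measured step, a 1.2-fold higher number from compound 2 to compound 3 (0.08 log units; within the scatter), concerns the amine side chain of the shared core and leaves the place changed here untouched, so no measured step bears directly on the change from compound 1 to compound 4. What the numbers do show is that compounds 2 and 3, which both carry a phenyl on their phenyl ring although they attach their rings to the core differently from compound 1, give values well below that of compound 1. On that basis the number for compound 4 is expected to come down, by roughly a 2.4-fold lower number from compound 1 to compound 4 (0.39 log units; beyond the scatter), while the lack of a matching step keeps the range wide. The estimate for compound 4 in this assay is 45 mg/kg, expected between 15 mg/kg and 130 mg/kg.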

Compound 4, dose for half-maximal effect: 30 mg/kg
Beside the measured number, compound 4's estimate is 1.5-fold (0.18 log units) above it; the range from low to high includes it.
By their numbers in this assay, from the lowest: compounds 2, 3 and 4 (each within the scatter of the next); then compound 1.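

In this assay, the place on the benzyl arm, on an aromatic carbon of a six-membered aromatic ring of carbon only and ortho to a group of 8 heavy atoms, now has a measured step of its own: phenyl in place of hydrogen gives a 3.7-fold lower number from compound 1 to compound 4 (0.56 log units; beyond the scatter). This step lies beyond the scatter and, unlike the step between the two amine side chains, shows that a change at this place on the core of compound 1 moves the read-out, here towards an effect at smaller amounts of compound. It rests on a single pair of compounds, and no measurement at hand accounts for the size or direction of the step.

The compounds shown leave open whether a smaller group at this place, such as a methyl, a chlorine or a methoxy, would give a similar step, or whether a full phenyl is needed, and how a carboxylic acid or an amine on the added ring would behave. They also leave open whether the same phenyl on another carbon of that ring would have a similar effect, and whether a methylamino side chain on compound 4 would change its number.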